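Dichlorophenyl Replaces Trifluoromethylphenyl on the Ring Nitrogen

The source may report more compounds than this note shows. Statements on the series, on what has been measured and on what is new or still open speak of the compounds shown alone.

Of the compounds shown here, three built on one shared core have so far been measured in a functional assay on PC-12 cells (Rattus norvegicus) for cytotoxicity, read by MTT assay, with stated times of 2 h and 24 h, tested at 10 uM; on this read-out higher numbers stand for a stronger effect at the one concentration tested and lower numbers for a weaker effect. Compound 1 `Oc1cc(C(F)(F)F)ccc1-c1nc(-c2ccccc2O)n(-c2ccc(F)cc2)n1` gives 99.8%, compound 2 `Oc1cc(C(F)(F)F)ccc1-c1nc(-c2ccccc2O)n(-c2ccc(I)cc2)n1` gives 105%, and compound 3 `Oc1cc(C(F)(F)F)ccc1-c1nc(-c2ccccc2O)n(-c2ccccc2C(F)(F)F)n1` gives 92.2%. On the numbers shown, compound 3 has the lowest value of the three, yet only one of its steps passes the scatter: the change a number 7.6 percentage points lower from compound 1 to compound 3 (within the scatter), whereas a number 12.8 percentage points lower from compound 2 to compound 3 (beyond the scatter). The remaining step, a number 5.2 percentage points higher from compound 1 to compound 2 (within the scatter), concerns a halogen swap on the aromatic carbon.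

Compound 4 `Oc1cc(C(F)(F)F)ccc1-c1nc(-c2ccccc2O)n(-c2ccc(Cl)cc2Cl)n1` departs from compound 3 at the aromatic nitrogen: 2,4-dichlorophenyl in place of 2-(trifluoromethyl)phenyl on an aromatic nitrogen. The two measured steps that bear on this position are those ending at compound 3, and each of them moved the read-out by only a few points, one within and one just beyond the scatter. With all three measured numbers sitting close together, the group on the aromatic nitrogen has so far shifted this assay little. Compound 4 is therefore expected to land near compound 3, with a step of a number 3.8 percentage points higher from compound 3 to compound 4 (within the scatter) that is not expected to exceed the scatter. The estimated value for compound 4 in this assay is 96%, with a range from 85% to 107%.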

Compound 4, a percentage reported as activity, at one concentration (the size of the read-out at that concentration, not a potency): 95.2%
Compound 4: the middle estimate sits 0.8 percentage points above what was measured; the range from low to high includes it.
By their numbers in this assay, from the lowest: compounds 3, 4, 1 and 2 (each within the scatter of the next, the first and the last beyond it).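

In this assay, 2,4-dichlorophenyl in place of 2-(trifluoromethyl)phenyl on the aromatic nitrogen gives a number 3 percentage points higher from compound 3 to compound 4 (within the scatter), so a fourth aryl group at this position leaves the read-out in the same narrow band. Compound 4 also stays within the scatter of the two compounds with a single halogen on that ring, with a number 4.6 percentage points lower from compound 1 to compound 4 (within the scatter) and a number 9.8 percentage points lower from compound 2 to compound 4 (within the scatter). The only step at this nitrogen beyond the scatter therefore remains a number 12.8 percentage points lower from compound 2 to compound 3 (beyond the scatter), and compound 4 does not repeat that separation, so it belongs to compound 3 alone rather than to every replacement of 4-iodophenyl among the compounds shown.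

All four compounds carry a substituted phenyl group on this nitrogen, which leaves open how the read-out would respond to a group without that ring, such as a longer alkyl chain, or to a phenyl ring bearing an amine or a carboxylic acid. No supporting measurement accompanies these results to account for why the values lie so close together.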